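The source may report more compounds than this note shows. Statements on the series, on what has been measured and on what is new or still open speak of the compounds shown alone.

Three compounds have been measured in an ADME assay on HPLF cells (Homo sapiens) for cytotoxicity, with a stated time of 24 h; on this read-out lower numbers stand for higher toxicity in this test and higher numbers for lower toxicity in this test:

compound 1 `O=C1/C(=C/c2ccccc2)CCC/C1=C\c1ccccc1[N+](=O)[O-]`: 26000 nM
compound 2 `O=C1/C(=C/c2ccccc2)CCC/C1=C\c1ccc([N+](=O)[O-])cc1`: 282000 nM
compound 3 `O=C1/C(=C/c2ccc(F)cc2)CCC/C1=C\c1ccc([N+](=O)[O-])cc1`: > 400000 nM

Compound 3 stands at the limit of > 400000 nM in this assay, at which 1 of the 3 values shown sits, so it has a limit and not an exact number. The next compound, compound 4 `CN(C)c1ccc(/C=C2\CCC/C(=C\c3ccc([N+](=O)[O-])cc3)C2=O)cc1`, keeps the shared core of compound 3 and changes one group: dimethylamino in place of fluoro on an aromatic carbon. In words, dimethylamino takes the place of fluoro on an aromatic carbon, para to a large group.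

Within the data shown here, only one measured step involves the same fluoro group: an at least 1.4-fold higher number from compound 2 to compound 3 (0.15 log units; that floor lies within the scatter). That step is small and rests on a limit, so it gives only weak guidance. Among the measured compounds shown here, no measured compound carries dimethylamino, so the size of this change is uncertain. Lower numbers do occur among these compounds, as compound 1 gives 26000 nM. A modest move toward lower numbers in this assay is therefore expected, although a further limit remains possible. The expected change is an at least 2.0-fold lower number from compound 3 to compound 4 (0.30 log units; that floor lies within the scatter). For compound 4 the estimated value is 200000 nM, with an expected range from 60000 nM to 400000 nM.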

Compound 4, half-maximal cytotoxic concentration: > 400000 nM
Compound 4 ended at the assay's limit (the forecaster's own chance of this, stated with the estimate: 30%); at least 2.0-fold (0.30 log units) between middle value and limit.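

Dimethylamino on this aromatic carbon, para to a large group, behaves in one respect as fluoro does: neither group gives a number that can be read in this assay. Compound 4 gives > 400000 nM, which is a limit of the assay, and since compound 3 also sits at a limit, the step between these two compounds cannot be read. With hydrogen on the same carbon as the reference, the comparison is an at least 1.4-fold higher number from compound 2 to compound 4 (0.15 log units; that floor lies within the scatter), so this change brings no sign of higher toxicity in this test, though the size of the step is not settled. Any real difference between the fluoro and dimethylamino compounds stays hidden because both have reached the top of the measurable range: the limit of > 400000 nM in this assay, at which 2 of the 4 values shown sit.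

The compounds shown leave open whether any other group on this carbon, such as a carboxylic acid, a methoxy group or a longer chain, would give a number below the limit. They also leave open how far the true values of compound 3 and compound 4 lie beyond that limit, and whether those values differ at all.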